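Removing a Chloro Group from the Core of Compound 1

The source may hold more compounds than are shown below. What is called first, only, known or untested is meant among the compounds shown, and "the series" means these compounds.

Compound 1: `ClCc1ccc(Cn2cnc3nc(Cl)nc(Cl)c32)cc1`; 1990 nM
Compound 2: `ClCc1cccc(Cn2cnc3c(Cl)nc(Cl)nc32)c1`; 1820 nM
Compound 3: `Nc1nc(Cl)c2ncn(Cc3cccc(CCl)c3)c2n1`; 2290 nM

These three compounds were tested in a functional assay on OVCAR-8 cells (Homo sapiens) for cytotoxicity, read by sulforhodamine B assay, with a stated time of 48 h; on this read-out higher numbers stand for weaker inhibition of growth and lower numbers for stronger inhibition of growth. Among them, compound 1 gives the second highest number of the three. Its nearest neighbour is compound 2, and the number for compound 1 is only slightly higher; its furthest is compound 3, and even that gap is within the scatter, so no order can be read from these values.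

Compound 4, `ClCc1ccc(Cn2cnc3ncnc(Cl)c32)cc1`, differs from compound 1 in one place: hydrogen in place of chloro on an aromatic carbon. Within the data shown here, the only measured step in this set, a 1.3-fold higher number from compound 2 to compound 3 (0.10 log units; within the scatter), exchanged one group for another on an aromatic carbon and stayed within the scatter. Among the measured compounds shown here, no measured pair shows a chloro group replaced by hydrogen, so that change carries no direct precedent here.

Given that the one known change to the core left this assay essentially unchanged, compound 4 is expected to give 2200 nM, with a range from 1000 nM to 5000 nM. That estimate means a step of a 1.1-fold higher number from compound 1 to compound 4 (0.04 log units; within the scatter), expected to lie within the scatter, with no clear direction.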

Compound 4, concentration for 50% growth inhibition: 3160 nM
Compound 4: the middle estimate sits 1.4-fold (0.16 log units) below what was measured; measured number inside the range.
By their numbers in this assay, from the lowest: compounds 2, 1, 3 and 4 (each within the scatter of the next).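

The chloro group on the aromatic carbon between two ring nitrogen atoms can be replaced by hydrogen, and in this assay this gives a 1.6-fold higher number from compound 1 to compound 4 (0.20 log units; within the scatter). Among these compounds, this is the first direct test of removing a chloro group from the core, and the step does not stand clear of the scatter. Compound 4 therefore shows no measurable need for this chloro group in this assay, although no evidence here explains the result.

On these data alone, it remains open how this position would respond to a different group, such as a methoxy group, a carboxylic acid or a longer chain. As far as these compounds go, it is also open whether the second chloro group on the core, which compound 4 retains, could be replaced by hydrogen with a similarly small step.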